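Replacing 4-hydroxycyclohexyl with 3,4-dinitrophenyl in compound 2

The source may hold more compounds than are shown below. What is called first, only, known or untested is meant among the compounds shown, and "the series" means these compounds.

Going by the values given here, in a functional assay on HL-60 cells (Homo sapiens) for inhibition, read by CCK-8 assay, with a stated time of 48 h (on this read-out lower numbers stand for stronger inhibition and higher numbers for weaker inhibition), compound 2 (`O=C(NCCNS(=O)(=O)c1ccc(-c2ccccc2O[C@H]2CC[C@H](O)CC2)s1)Nc1ccc([N+](=O)[O-])cc1`) gives 8900 nM as the only actual number so far. Compound 1 (`O=C(NCCNS(=O)(=O)c1ccc(-c2ccccc2O[C@H]2CC[C@@H](O)CC2)s1)Nc1ccc([N+](=O)[O-])cc1`) gives only a limit of the assay (> 20000 nM). Compound 3 (`O=[N+]([O-])c1ccc(NC(=S)NCCNS(=O)(=O)c2ccc(-c3ccccc3OCc3ccccc3)s2)cc1`) also gives only a limit (> 50000 nM). Among the compounds with values here, the single measured step (an at least 2.2-fold lower number from compound 1 to compound 2 (0.35 log units; beyond the scatter)) involves configuration alone (the fact that compounds 1 and 2 differ only in the configuration as drawn) and rests on a limit (the limit of > 20000 nM in this assay, at which 1 of the 3 values shown sits). Compound 4 (`O=C(NCCNS(=O)(=O)c1ccc(-c2ccccc2Oc2ccc([N+](=O)[O-])c([N+](=O)[O-])c2)s1)Nc1ccc([N+](=O)[O-])cc1`) has 3,4-dinitrophenyl in place of 4-hydroxycyclohexyl on an oxygen on an aromatic ring. Within the data shown here, no measured step covers this exchange. Among the measured compounds shown here, a modest step toward weaker inhibition in this assay is expected, similar in size to the one measured step (an at least 2.2-fold lower number from compound 1 to compound 2 (0.35 log units; beyond the scatter)). The expected change is a 1.8-fold higher number from compound 2 to compound 4 (0.25 log units; within the scatter) in this estimate. For compound 4 the estimated value is 16000 nM (expected range 4000 nM to 50000 nM).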

Compound 4, half-maximal inhibitory concentration: 340 nM
Compound 4: the middle estimate sits 47-fold (1.67 log units) above what was measured; measured number outside the range, below it.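

In this assay, this oxygen had so far shown only a change of configuration; exchanging the whole group there gives a 26-fold lower number from compound 2 to compound 4 (1.42 log units; beyond the scatter), so 3,4-dinitrophenyl in place of 4-hydroxycyclohexyl brings a large step toward stronger inhibition. The second step, an at least 58-fold lower number from compound 1 to compound 4 (1.76 log units; beyond the scatter), points the same way but rests on a limit: the limit of > 20000 nM in this assay, at which 1 of the 4 values shown sits.

The compounds shown leave open whether a plain phenyl or a 4-aminophenyl on this oxygen would do the same. The part of the aromatic ring and that of the two nitro groups therefore cannot be separated.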